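Trimming Ethyl to Methyl on Compound 1

The compounds below may be only part of what the source reports. "The series", "measured", "known", "first", "only" and "open" are said of these compounds alone.

- compound 1 `CCc1ccc(SCc2ccc(C(=O)Nc3ccccc3N)cc2)cc1`: 25.7%
- compound 2 `Nc1ccccc1NC(=O)/C=C/c1ccc(CSc2ccc(C(F)(F)F)cn2)cc1`: 12.1%

Both compounds were tested in a functional assay on SMMC-7721 cells (Homo sapiens) for inhibition, read by CCK-8 assay, with a stated time of 72 h, tested at 2 uM; a lower number here means less inhibition of growth, a higher number more inhibition of growth at the concentration tested. Compound 1 holds the higher of the two numbers, and the gap down to compound 2 lies beyond the usual scatter. These two compounds differ in more than one place, so their gap says little about a single small edit.

The next compound, compound 3 `Cc1ccc(SCc2ccc(C(=O)Nc3ccccc3N)cc2)cc1`, keeps the core of compound 1 and changes one group: hydrogen in place of methyl on a saturated chain carbon bound to an aromatic carbon. In words, hydrogen stands in place of methyl on a saturated chain carbon bound to an aromatic carbon, which turns 4-ethylphenyl into 4-methylphenyl. Among the measured compounds shown here, no measured pair here shows this kind of change, so the expectation rests on how small the edit is. Little movement is expected, with nothing beyond the scatter and no firm direction. The expected step is a number 2.7 percentage points lower from compound 1 to compound 3 (within the scatter). For compound 3 the estimated value is 23%, with an expected range from 10% to 38%.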

Compound 3, percent growth inhibition at one concentration: 25.1%
Compound 3: the middle estimate sits 2.1 percentage points below what was measured; the measured number falls inside the stated range.
By their numbers in this assay, from the lowest: compound 2; then compounds 3 and 1 (each within the scatter of the next).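

Trimming 4-ethylphenyl to 4-methylphenyl gives a number 0.6 percentage points lower from compound 1 to compound 3 (within the scatter) in this assay and so leaves the reading at this position unchanged within the scatter. Among the compounds shown here, this is the only comparison here in which just one place differs, something the gap between compound 1 and compound 2 could not offer, and it shows that this position can lose one chain carbon without a clear loss of growth inhibition at the concentration tested. No measurement shown explains why these two compounds read alike.

On these data alone, it remains open whether a longer chain such as propyl, or a quite different group such as an amine or a carboxylic acid, would read the same at this position. A step this small also gives no direction for further edits here, so the result cannot show which way such changes would go.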